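Swapping a Fluoro for a Methyl on the Aryl Ring

A few compounds are considered here, and "the series" means these few. Any claim that something is new, unique, unknown or untested is made for them only; others in the source may bear on it.

Within the data shown here, compound 1 `CC1(C)[C@H]2CC[C@]1(C)N(Cc1cn(-c3ccccc3F)nn1)C(=O)C2` gives the lowest of the two numbers measured so far in a functional assay on SGC-7901 cells (Homo sapiens) for inhibition, read by MTT assay, with a stated time of 24 h (on this read-out lower numbers stand for stronger inhibition and higher numbers for weaker inhibition), where compound 1 gives 300 nM. Among the measured compounds shown here, its only neighbour, compound 2 `CC1(C)[C@H]2CC[C@]1(C)N(Cc1cn(-c3ccc(Br)cc3)nn1)C(=O)C2`, gives 450 nM, and the step of a 1.5-fold higher number from compound 1 to compound 2 (0.18 log units; within the scatter) sits within the scatter, so the two cannot be ranked. The unmeasured compound 3 `Cc1ccccc1-n1cc(CN2C(=O)C[C@@H]3CC[C@@]2(C)C3(C)C)nn1` differs from compound 1 in one place: methyl in place of fluoro on an aromatic carbon. Cut one bond further out, this reads as 2-fluorophenyl to 2-methylphenyl. For the measured compounds named here, the single measured step alters a different part of this ring, from 2-fluorophenyl to 4-bromophenyl, and it was small, so it shows only that the one swap tried on this ring hardly moved the number. For compound 3 the expected step of a 1.2-fold higher number from compound 1 to compound 3 (0.07 log units; within the scatter) is therefore none beyond the scatter. The estimate for compound 3 is 350 nM, with a range from 150 nM to 800 nM.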

Compound 3, half-maximal inhibitory concentration: 350 nM
Compound 3: the middle estimate sits on the measured number at the digits printed, and the stated range covers the measured number.
By their numbers in this assay, from the lowest: compounds 1, 3 and 2 (each within the scatter of the next).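

In this assay, among these compounds, the step of a 1.2-fold higher number from compound 1 to compound 3 (0.07 log units; within the scatter) is the first measured change at the fluoro position itself, on the aromatic carbon ortho to a large group, and it shows that fluoro and methyl cannot be told apart there on this read-out. The step of a 1.3-fold lower number from compound 2 to compound 3 (0.11 log units; within the scatter) also stays within the scatter, so 2-methylphenyl and 4-bromophenyl cannot be ranked either, and the three aryl groups shown remain unseparated. No outside measurement bears on this result, so the data offer no explanation for it.

On these data alone, whether an amine, a carboxylic acid or a longer chain such as propyl at this position would give a step beyond the scatter remains open. Also open, as far as these compounds go, is whether a change on the shared core, away from the aryl group, would do so.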